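Branching the alkanoyl chain of a bisacylhydrazine

The source may report more compounds than this note shows. Statements on the series, on what has been measured and on what is new or still open speak of the compounds shown alone.

Measured compounds:
Compound 1, `Cc1cccc(C(=O)NN(C(=O)c2ccccc2Cl)C(C)(C)C)c1`, 603 nM
Compound 2, `CCCCCC(=O)N(NC(=O)c1cc(C)cc(C)c1)C(C)(C)C`, 8710 nM

Both compounds were examined in an assay on cells for agonist activity at ecdysone receptor (Bombyx mori), read by a luciferase reporter, with a stated time of 24 h; a lower number here means that less compound is needed, a higher number that more compound is needed for the effect. Among the compounds with values here, compound 1 gives 603 nM, while compound 2 gives 8710 nM, the higher of the two numbers; the gap between compound 1 and compound 2 lies beyond the usual scatter, and no single-point step connects the two.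

Compound 3, `Cc1cc(C)cc(C(=O)NN(C(=O)CCCC(C)C)C(C)(C)C)c1`, has not been measured in this assay. It differs from compound 2 by methyl in place of hydrogen on a saturated chain carbon bound to two saturated chain carbons. Within the data shown here, there is no measured pair here that shows what such a change does. The account therefore expects only a small step from compound 2 to compound 3, if any, leaning toward a lower number, and one that may well stay inside the scatter: a 1.7-fold lower number from compound 2 to compound 3 (0.24 log units; within the scatter). On that basis compound 3 is estimated at 5000 nM, with a plausible range from 1500 nM to 15000 nM.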

Compound 3, half-maximal effective concentration: > 100000 nM
Compound 3: only a limit was reported (the forecaster's own chance of this, stated with the estimate: 5%); middle value at least 20-fold (1.30 log units) from the limit.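

In this assay compound 3 gives > 100000 nM, a limit of the assay and not a number. Methyl in place of hydrogen on a saturated chain carbon bound to two saturated chain carbons, read one bond further out as butyl to isopentyl, comes with an at least 11-fold higher number from compound 2 to compound 3 (1.05 log units; beyond the scatter), so a single added methyl at this place is enough for a step beyond the scatter, something the earlier compounds could not show. The true size of that step stays unknown, as the reading ends at the limit: the limit of > 100000 nM in this assay, at which 1 of the 3 values shown sits.

The compounds shown leave open whether this step belongs to the branch itself or simply to the added carbon. A longer unbranched chain, or a hydroxyl or fluorine on the same carbon, would bear on that question.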